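The compounds below may be only part of what the source reports. "The series", "measured", "known", "first", "only" and "open" are said of these compounds alone.

Compound 1 `Cc1ccc(C2C(C#N)=C(N)N(c3ccc(S(N)(=O)=O)cc3)C3=C2C(=O)CCC3)cc1` is the starting point. In a functional assay on Ehrlich cells (Mus musculus) for antiproliferative activity, read by trypan blue exclusion, with a stated time of 2 h (on this read-out lower numbers stand for stronger inhibition and higher numbers for weaker inhibition), compound 1 gives 50 ug/mL. Compound 2 `COc1cc(CC2C(C#N)=C(N)N(c3ccc(S(N)(=O)=O)cc3)C3=C2C(=O)CCC3)ccc1O` carries a 4-hydroxy-3-methoxybenzyl group on the saturated ring carbon and in this assay compound 2 gives 25 ug/mL, a step described as a 2.0-fold lower number from compound 1 to compound 2 (0.30 log units; within the scatter). Compound 3 `N#CC1=C(N)N(c2ccc(S(N)(=O)=O)cc2)C2=C(C(=O)CCC2)C1c1c(O)ccc2ccccc12` carries a 2-hydroxynaphthalen-1-yl group at the same carbon. For compound 3 the result in this assay is a limit of the assay, > 100 ug/mL, as noted in the limit of > 100 ug/mL in this assay, at which 1 of the 3 values shown sits. The step from compound 1 is an at least 2.0-fold higher number from compound 1 to compound 3 (0.30 log units; that floor lies within the scatter), and that from compound 2 is an at least 4.0-fold higher number from compound 2 to compound 3 (0.60 log units; beyond the scatter).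

Compound 4 `N#CC1=C(N)N(c2ccc(S(N)(=O)=O)cc2)C2=C(C(=O)CCC2)C1c1ccco1` is not yet measured. Relative to compound 1 the change is furan-2-yl in place of 4-methylphenyl on a saturated ring carbon. The measured steps at this carbon span from a change within the scatter to a limit, and none involves a five-membered aromatic ring with 1 hetero atom, so the evidence is thin. Compound 4 is therefore expected to give about 50 ug/mL in this assay, a step of no change at the digits printed from compound 1 to compound 4 (within the scatter), with a range from 20 ug/mL to 150 ug/mL.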

Compound 4, half-maximal inhibitory concentration: > 100 ug/mL
Compound 4: only a limit was reported; the forecaster's own chance of this, stated with the estimate: 20%; at least 2.0-fold (0.30 log units) between middle value and limit.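

In this assay compound 4 joins compound 3 at a limit of the assay rather than a number, so a second, quite different group on this saturated ring carbon gives no readable value: the limit of > 100 ug/mL in this assay, at which 2 of the 4 values shown sit. The exchange for furan-2-yl shows an at least 2.0-fold higher number from compound 1 to compound 4 (0.30 log units; that floor lies within the scatter), a floor that does not by itself establish a loss, while the comparison with the 4-hydroxy-3-methoxybenzyl group shows an at least 4.0-fold higher number from compound 2 to compound 4 (0.60 log units; beyond the scatter). The step between the two limits cannot be read.

The compounds shown do not tell whether a thiophen-2-yl or a pyridin-3-yl group on this carbon would give a readable value or would also end at the limit. They also cannot separate the part played by the methylene link of the benzyl group from that of its hydroxy and methoxy substituents.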